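A Formyl-to-Ether Swap in a Weakly Cytotoxic Series

This account rests on a few compounds, and the source may have more. Where it says the series, first, only, none or still open, it means among the compounds named here.

Compound 1 `C=CCn1c(-c2ccc(OC)cc2C=C)cc2ccccc2c1=O`: 17200 nM
Compound 2 `C=CCn1c(-c2cc(OC)c(OC)cc2C=O)cc2ccccc2c1=O`: 76300 nM
Compound 3 `COc1ccc2c(c1)C=CCn1c-2cc2ccccc2c1=O`: 6480 nM

In a functional assay on A549 cells (Homo sapiens) for cytotoxicity, read by MTT assay, with a stated time of 48 h (a higher number here means a weaker inhibitor, a lower number a stronger inhibitor), compound 2 gives 76300 nM, the highest number of the three measured compounds. Compound 1 lies nearest to it in this assay, and compound 3, which gives 6480 nM, lies furthest away; both gaps are beyond the usual scatter.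

Compound 4 `C=CCn1c(-c2cc(OC)c(OC)cc2COCOC)cc2ccccc2c1=O` differs from compound 2 in one place: (methoxymethoxy)methyl in place of formyl on an aromatic carbon. The formyl group is replaced by a (methoxymethoxy)methyl group on the same aromatic carbon, ortho to a large group, meta to one methoxy group and para to the other.

For the measured compounds named here, no measured pair shows this change, so the expectation rests on compound 2 alone. Compound 4 is expected to move only modestly, if at all, toward a lower number, a step of a 1.9-fold lower number from compound 2 to compound 4 (0.28 log units; within the scatter). Compound 4 is estimated at 40000 nM, within 12000 nM to 150000 nM.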

Compound 4, half-maximal inhibitory concentration: 88100 nM
Beside the measured number, compound 4's estimate is 2.2-fold (0.34 log units) below it; low and high end bracket the measured number.
By their numbers in this assay, from the lowest: compound 3; then compound 1; then compounds 2 and 4 (each within the scatter of the next).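

In this assay, for the compounds shown here, the step is a 1.2-fold higher number from compound 2 to compound 4 (0.06 log units; within the scatter), the first one-place comparison in this set. It shows that this aromatic carbon tolerates the exchange of formyl for the larger (methoxymethoxy)methyl with no change beyond the scatter, so the formyl group is not required for the high number of compound 2. Nothing measured here gives a reason for this result.

As far as these compounds go, whether an amine or a carboxylic acid on this aromatic carbon would move the number remains open. Also open, from the compounds shown here alone, is whether any group here can give a clearly lower number.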